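The compounds below may be only part of what the source reports. "The series", "measured", "known", "first", "only" and "open" are said of these compounds alone.

Compound 2 `CCCCCCCCCCCC#Cc1cn([C@H]2CC[C@@H](CO)O2)c(=O)[nH]c1=O` gives in an ADME assay on Vero cells (Homo sapiens) for cytotoxicity against Vero (Chlorocebus sabaeus), read by MTT assay (a higher number here means that more compound is tolerated, a lower number that less compound is tolerated), the value > 100 ug/mL, which is a limit of the assay and not a number. Compound 1 `CCCCCCCCC#Cc1cn([C@H]2CC[C@@H](CO)O2)c(=O)[nH]c1=O` gives in this assay the value > 100 ug/mL, likewise a limit and not a number. The step that the two limits leave unreadable from compound 1 to compound 2 therefore cannot be read, because of the limit of > 100 ug/mL in this assay, at which 2 of the 2 values shown sit. Compound 3 `CCCCCCCCCC#Cc1cn([C@H]2CC[C@@H](CO)O2)c(=O)[nH]c1=O` is not yet measured in this assay. It differs from compound 2 by hydrogen in place of ethyl on a saturated chain carbon, nine bonds along the chain from a triple-bonded carbon, a shortening of the same saturated chain that the step from compound 1 to compound 2 lengthened. Going by the values given here, the only measured step bearing on this change is a step that the two limits leave unreadable from compound 1 to compound 2, and it yields no readable size. The expected step that the limit leaves unreadable from compound 2 to compound 3 is accordingly none beyond the scatter. Compound 3 is expected to give 150 ug/mL in this assay, within 100 ug/mL to 300 ug/mL, most likely reported again as a limit.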

Compound 3, half-maximal cytotoxic concentration: > 100 ug/mL
Compound 3 ended at the assay's limit; the forecaster's own chance of this, stated with the estimate: 85%; the middle value does not contradict the limit.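

Compound 1, compound 2 and compound 3 all end at a limit and not a number in this assay, so no step among them can be read: the limit of > 100 ug/mL in this assay, at which 3 of the 3 values shown sit.

The compounds shown leave open whether any saturated chain length on the shared core would give a readable value in this assay.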